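The compounds below may be only part of what the source reports. "The series", "measured", "known", "first", "only" and "open" are said of these compounds alone.

Cytotoxicity in this study is read with a functional assay on SK-BR-3 cells (Homo sapiens) for cytotoxicity, read by MTT assay, with a stated time of 72 h; a lower number here means that less compound is needed, a higher number that more compound is needed for the effect. Compound 1 `COc1ccc(Nc2cc(C)oc(=O)c2)cc1` reaches only the limit of this assay, giving > 30 uM, which is a boundary of the measurement and not a number. Where compound 1 stands is therefore simply stated: the limit of > 30 uM in this assay, at which 1 of the 2 values shown sits. Going by the values given here, a second compound, compound 2 `O=c1cc(Nc2ccccc2)cc(-c2ccccc2)o1`, differs from compound 1 in more than one place, so no single step joins the two; in this assay compound 2 gives 0.13 uM, a true number well inside the measurable window. Compound 3 `COc1ccc(Nc2cc(/C=C/c3ccccc3)oc(=O)c2)cc1` is not yet measured. It differs from compound 1 in one place only: 2-phenylethenyl in place of methyl on an aromatic carbon. The two values shown suggest that a larger, aromatic group on the shared core can go together with far less compound being needed, although compound 2 also differs elsewhere, so that reading stays uncertain. The expected step is an at least 20-fold lower number from compound 1 to compound 3 (1.30 log units; beyond the scatter), in the direction of less compound needed. The estimate for compound 3 in this assay is 1.5 uM, within a range from 0.2 uM to 12 uM, with some chance that only a limit is again reported.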

Compound 3, concentration for half-maximal effect: 0.083 uM
For compound 3 the middle estimate is 18-fold (1.26 log units) above the measured one, outside the stated range (below it).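

Going by these compounds alone, with only one place changed, this is the first clean reading of this position: in this assay, 2-phenylethenyl in place of methyl on the aromatic carbon next to the ring oxygen gives an at least 360-fold lower number from compound 1 to compound 3 (2.55 log units; beyond the scatter). Compound 2 could only hint at a link between a larger aromatic group and a lower number, since it differs from compound 1 in more than one place, whereas this single change ties the drop directly to this position and this group. The step gives only a minimum for the true size of the change, because compound 1 sits at a limit of the assay and not at a number: the limit of > 30 uM in this assay, at which 1 of the 3 values shown sits.

The 2-phenylethenyl group brings in both an aromatic ring and a double bond outside that ring, and the compounds shown cannot tell whether one of these alone, or simply the greater size, goes with the lower number. As far as these compounds go, a saturated 2-phenylethyl chain, a plain butyl chain or an amine at this same carbon would each test a different part of that question, and how any of them would read remains open.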